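A few compounds are considered here, and "the series" means these few. Any claim that something is new, unique, unknown or untested is made for them only; others in the source may bear on it.

Three compounds share a cytotoxicity read-out in an ADME assay on HEK293 cells (Homo sapiens) for cytotoxicity, with a stated time of 72 h (on this read-out lower numbers stand for an effect already at smaller amounts and higher numbers for an effect only at larger amounts of compound), and in every case the result is a limit of the assay rather than a number. Compound 1 `C=C[C@@](C)(/C=C/c1ccc(O)cc1)CC/C=C/C(=O)OCC` gives in this assay a limit of > 36600 nM. Compound 2 `C=C[C@@](C)(/C=C/c1ccc(O)cc1)CC/C=C/C#N` likewise gives in this assay a limit of > 36600 nM. Compound 3 `COc1ccc(/C=C/[C@@](C)(/C=C/c2ccc(O)c(/C=C/C#N)c2)CCC=C(C)C)cc1` gives in this assay a limit of > 36600 nM. The step that the two limits leave unreadable from compound 2 to compound 1 is ethoxycarbonyl in place of cyano on a double-bonded chain carbon bound to a double-bonded chain carbon, and its size cannot be read because both of its ends sit at the limit of > 36600 nM in this assay, at which 3 of the 3 values shown sit. The cores of compound 2 and compound 3 differ, but that difference is not broken down here. Compound 4 `CCOC(=O)/C=C/c1cc(/C=C/[C@](C)(/C=C/c2ccc(OC)cc2)CCC=C(C)C)ccc1O` is the not yet measured partner of compound 3, reached by the same kind of change, (ethoxycarbonyl in place of cyano on a double-bonded chain carbon bound to a double-bonded chain carbon). Since the earlier instance of this change left no readable step, the expectation for compound 4 in this assay rests only on all three measured values sitting at the same limit, (the limit of > 36600 nM in this assay, at which 3 of the 3 values shown sit). The step that the limit leaves unreadable from compound 3 to compound 4 is therefore expected to be small. Compound 4 is estimated at 50000 nM, with a range from 30000 nM to 120000 nM, and most likely again reported only as a limit.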

Compound 4, half-maximal effective concentration: > 36600 nM
Compound 4 was reported as a limit; the forecaster's own chance of this, stated with the estimate: 85%; the middle value does not contradict the limit.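

Compound 3 and compound 4 give no readable step, as both results are limits of the assay rather than numbers: the limit of > 36600 nM in this assay, at which 4 of the 4 values shown sit. The compounds shown leave open where any of them would reach a half-maximal effect in this assay, and whether ethoxycarbonyl in place of cyano changes that concentration at all.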